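Aryl swap on the aromatic nitrogen: compound 2 to compound 4

This account rests on a few compounds, and the source may have more. Where it says the series, first, only, none or still open, it means among the compounds named here.

Compound 2 `N#CC1=C(N)Oc2c(c3nc4ccccc4nc3c3ccccc23)C12C(=O)N(Cc1cnnn1-c1ccc(Cl)cc1)c1ccccc12` carries the 4-chlorophenyl on the aromatic nitrogen. In a functional assay on MCF7 cells (Homo sapiens) for antiproliferative activity, read by MTT assay, with a stated time of 48 h (a lower number here means a stronger inhibitor, a higher number a weaker inhibitor), compound 2 gives only a limit, > 50000 nM. Compound 1 `Cc1ccccc1-n1nncc1CN1C(=O)C2(C(C#N)=C(N)Oc3c2c2nc4ccccc4nc2c2ccccc32)c2ccccc21` is the 2-methylphenyl analogue. In this assay compound 1 likewise reaches only a limit, > 50000 nM. Compound 3 `N#CC1=C(N)Oc2c(c3nc4ccccc4nc3c3ccccc23)C12C(=O)N(Cc1cnnn1-c1ccccc1Br)c1ccccc12` carries the 2-bromophenyl. In this assay compound 3 too stands at a limit, > 50000 nM. Hence the steps a step that the two limits leave unreadable from compound 1 to compound 2, a step that the two limits leave unreadable from compound 1 to compound 3 and a step that the two limits leave unreadable from compound 2 to compound 3 cannot be sized; all three values sit at the limit of > 50000 nM in this assay, at which 3 of the 3 values shown sit. Compound 4 `Cc1ccc(-n2nncc2CN2C(=O)C3(C(C#N)=C(N)Oc4c3c3nc5ccccc5nc3c3ccccc43)c3ccccc32)cc1Cl` is the next point in the same position: 3-chloro-4-methylphenyl in place of 4-chlorophenyl on an aromatic nitrogen. The three measured steps bear on it only in that exchanging the aryl on the aromatic nitrogen has so far never brought a compound off the limit; no size can be read from them. The expectation is therefore a step that the limit leaves unreadable from compound 2 to compound 4 in this assay, which is to say none beyond the scatter. Compound 4 is estimated at 80000 nM (30000 nM to 300000 nM), most likely reported again only as a limit.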

Compound 4, half-maximal inhibitory concentration: > 50000 nM
Compound 4: a limit, no number; the forecaster's own chance of this, stated with the estimate: 85%; the middle value is on the limit's open side.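

Compound 4 gives > 50000 nM in this assay, again a limit. No step from compound 1, compound 2 or compound 3 to compound 4 can be read: the limit of > 50000 nM in this assay, at which 4 of the 4 values shown sit.

The compounds shown leave open whether any aryl on the aromatic nitrogen gives a measurable value in this series.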